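Shortening the chain: from compound 1 to 3, then 2 to 4

This account rests on a few compounds, and the source may have more. Where it says the series, first, only, none or still open, it means among the compounds named here.

Measured so far in a functional assay on HeLa cells (Homo sapiens) for inhibition; on this read-out lower numbers stand for stronger inhibition and higher numbers for weaker inhibition:
compound 1 `CC(C)=CCC/C(C)=C/C[C@]12C[C@@H](CC=C(C)C)C(C)(C)[C@](CC=C(C)C)(C(=O)C(C(=O)c3ccc(O)c(O)c3)=C1O)C2=O`: 11.7 ug/mL
compound 2 `CC(C)=CCC/C(C)=C/C[C@@H]1C[C@@]2(C/C=C(\C)CCC=C(C)C)C(=O)CC(=O)[C@](CC=C(C)C)(C2=O)C1(C)C`: a limit, > 20 ug/mL
compound 3 `CC(C)=CC[C@@H]1C[C@]2(CC=C(C)C)C(=O)[C@@](CC=C(C)C)(C(=O)C(C(=O)c3ccc(O)c(O)c3)=C2O)C1(C)C`: 13.7 ug/mL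

Compound 3 arises from compound 1 by hydrogen in place of 3-methylbut-2-en-1-yl on a saturated chain carbon bound to a double-bonded chain carbon, and this gave a 1.2-fold higher number from compound 1 to compound 3 (0.07 log units; within the scatter). Compound 4 `CC(C)=CCC/C(C)=C/C[C@@H]1C[C@@]2(CC=C(C)C)C(=O)CC(=O)[C@](CC=C(C)C)(C2=O)C1(C)C` arises from compound 2 by the same change, (hydrogen in place of 3-methylbut-2-en-1-yl on a saturated chain carbon bound to a double-bonded chain carbon), at a place described in the same words. How the core of compound 2 differs from the core of compound 1 is not broken down here. For compound 2 only a limit is known in this assay, (the limit of > 20 ug/mL in this assay, at which 1 of the 3 values shown sits), so the starting point of the second step is itself open.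

Given that the earlier step lay within the scatter, the step from compound 2 to compound 4 in this assay is expected to be a step that the limit leaves unreadable from compound 2 to compound 4. Compound 4 is accordingly estimated at 25 ug/mL, likely between 12 ug/mL and 60 ug/mL, with a fair chance that only a limit is again reported.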

Compound 4, half-maximal inhibitory concentration: 9.69 ug/mL
Compound 4: middle estimate off by 2.6-fold (0.41 log units), on the high side, outside the stated range (below it).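

In this assay, hydrogen in place of 3-methylbut-2-en-1-yl on a saturated chain carbon bound to a double-bonded chain carbon gave an at least 2.0-fold lower number from compound 2 to compound 4 (0.31 log units; beyond the scatter), so on this core the shorter chain keeps measurable inhibition. Compound 2 stands only as a limit, > 20 ug/mL. The step therefore has a known direction but no exact size, and the comparison with the other core does not establish whether the change carries over unaltered: the same change on two cores in this assay, a 1.2-fold higher number (0.07 log units; within the scatter) from compound 1 to compound 3 and an at least 2.0-fold lower number (0.31 log units; beyond the scatter) from compound 2 to compound 4; the limit leaves it open whether they differ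

Open, as far as these compounds go, is what an ethyl group, a longer chain or an amine would give at this place on either core. Also open, from the compounds shown here alone, is whether the same change behaves alike on any core beyond these two.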